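The source may hold more compounds than are shown below. What is called first, only, known or untested is meant among the compounds shown, and "the series" means these compounds.

Measured in a functional assay on MDA-MB-231 cells (Homo sapiens) for cytotoxicity, read by ELISA, with a stated time of 2 days; a higher number here means a weaker inhibitor, a lower number a stronger inhibitor:
- compound 1 `Oc1cccc(-c2cc(-c3ccccc3)cc(-c3ccco3)n2)c1` gives 13700 nM
- compound 2 `Oc1ccccc1-c1cc(-c2ccccc2)nc(-c2ccco2)c1` gives 4600 nM
- compound 3 `Oc1cccc(-c2cc(-c3ccccc3)nc(-c3cccs3)c2)c1` gives 17700 nM

Compound 3 lies within the scatter of compound 1, so these two are not ranked against each other. Compound 2 has a lower number than compound 3, and that gap lies beyond the scatter. Among the measured compounds shown here, the measured compounds differ from one another in more than one place, so the data contain no single-place step to serve as a yardstick.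

The next compound is compound 4 `Oc1cccc(-c2cc(-c3ccccc3)nc(-c3ccccn3)c2)c1`, which carries pyridin-2-yl in place of thiophen-2-yl on an aromatic carbon of a six-membered aromatic ring with 1 nitrogen, next to the ring nitrogen: pyridin-2-yl in place of thiophen-2-yl on an aromatic carbon. The rest of compound 3 is kept.

For the measured compounds named here, the only guide to size is the spread of the set, from compound 2 at 4600 nM to compound 3 at 17700 nM, so a large move is not expected. In this assay the expected result is a 1.5-fold lower number from compound 3 to compound 4 (0.17 log units; within the scatter), an estimated small shift towards a lower number that stays within the scatter. The estimate for compound 4 is 12000 nM, with an expected range from 4000 nM to 30000 nM.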

Compound 4, half-maximal inhibitory concentration: 18700 nM
Beside the measured number, compound 4's estimate is 1.6-fold (0.19 log units) below it, and the stated range covers the measured number.
By their numbers in this assay, from the lowest: compound 2; then compounds 1, 3 and 4 (each within the scatter of the next).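

In this assay, among the compounds shown here, the first single-place step is pyridin-2-yl in place of thiophen-2-yl on an aromatic carbon, next to the ring nitrogen, and it reads as a 1.1-fold higher number from compound 3 to compound 4 (0.02 log units; within the scatter) with the rest of the structure kept. At this position, then, the five-membered sulfur-containing aromatic ring and the six-membered nitrogen-containing aromatic ring cannot be told apart in this read-out, so this exchange gives no handle on the number, and ring size and hetero atom cannot be separated here, as both change in the same step. No measured information is available to account for this outcome.

Still open, on these data alone, is whether a group of another kind at the same place, such as a morpholine, a carboxylic acid or a short alkyl chain, would give a step beyond the scatter. For the compounds shown here, also open is whether the same exchange of rings would read the same way on the core of compound 2, the one compound here set apart from the others by its number.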